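The compounds below may be only part of what the source reports. "The series", "measured", "known", "first", "only" and "open" are said of these compounds alone.

Measured so far in a functional assay on cells for antagonist activity at C-X-C chemokine receptor type 4 (Homo sapiens), read by fluorescence and calcium flux, with stated times of 25 min and 90 s; on this read-out higher numbers stand for weaker inhibition and lower numbers for stronger inhibition:
compound 1, `c1ccc2c(c1)CN[C@@H](CN(CCCCNCc1ccncc1)[C@H]1CCCc3cccnc31)C2` — 22.7 nM
compound 2, `c1ccc(CNCCCCN(C[C@H]2Cc3ccccc3CN2)[C@H]2CCCc3cccnc32)cc1` — 20.1 nM
compound 3, `c1ccc2c(c1)CN[C@@H](CN(CCCCNC1CCCCC1)[C@H]1CCCc3cccnc31)C2` — 75.2 nM

Compound 3 gives the highest number of the three, so it is the weakest inhibitor in this assay: the step of a 3.3-fold higher number from compound 1 to compound 3 (0.52 log units; beyond the scatter) and the step of a 3.7-fold higher number from compound 2 to compound 3 (0.57 log units; beyond the scatter) both lie beyond the scatter, while compound 1 and compound 2 differ only by a 1.1-fold lower number from compound 1 to compound 2 (0.05 log units; within the scatter). Both steps onto compound 3 replace a (pyridin-4-yl)methyl or benzyl group on the amine nitrogen with a cyclohexyl group.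

Compound 4, `O=S1(=O)CCC(NCCCCN(C[C@H]2Cc3ccccc3CN2)[C@H]2CCCc3cccnc32)CC1`, carries the change (1,1-dioxothian-4-yl in place of cyclohexyl on an amine nitrogen). The ring on that nitrogen stays saturated and six-membered, but it now contains one hetero atom and brings two hydrogen-bond acceptors. Going by the values given here, no measured pair shows a swap of this kind; the only steps that touch this position, those leading to compound 3, concern aromatic against saturated rings and were modest. With the ring still saturated, the step of a 1.2-fold lower number from compound 3 to compound 4 (0.06 log units; within the scatter) is expected to be small and its direction is uncertain. Compound 4 is therefore estimated at 65 nM, within a range from 20 nM to 220 nM.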

Compound 4, half-maximal inhibitory concentration: 45.5 nM
Compound 4: the middle estimate sits 1.4-fold (0.15 log units) above what was measured; low and high end bracket the measured number.
By their numbers in this assay, from the lowest: compounds 2, 1, 4 and 3 (each within the scatter of the next, the first and the last beyond it).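

In this assay the step of a 1.7-fold lower number from compound 3 to compound 4 (0.22 log units; within the scatter) stays within the scatter, so on this amine nitrogen the two saturated six-membered rings cannot be told apart, even though 1,1-dioxothian-4-yl brings a hetero atom into the ring and has hydrogen-bond acceptors that cyclohexyl lacks. Compared with the aromatic groups, the new ring gives a split picture: the step of a 2.3-fold higher number from compound 2 to compound 4 (0.35 log units; beyond the scatter) lies beyond the scatter, whereas the step of a 2.0-fold higher number from compound 1 to compound 4 (0.30 log units; within the scatter) lies within it, while cyclohexyl in compound 3 was separated beyond the scatter from both compound 1 and compound 2. No measurement given here accounts for any of these results.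

The compounds shown leave open whether other saturated six-membered rings on this nitrogen, such as piperidin-4-yl with a ring nitrogen or tetrahydropyran-4-yl with a ring oxygen, would read like cyclohexyl and 1,1-dioxothian-4-yl. They also leave open what a carboxylic acid or a hydroxyl group on the cyclohexyl ring would do, and whether a smaller ring such as cyclopentyl would keep the number in the same range.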